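Replacing Amino by Butyl on the Imine Nitrogen

The source may report more compounds than this note shows. Statements on the series, on what has been measured and on what is new or still open speak of the compounds shown alone.

Compound 1 `O=c1[nH]c2ccccc2cc1/C=N/CCO` gives 1210000 nM in a functional assay, read by spectrophotometry, with a stated time of 3 min; on this read-out higher numbers stand for weaker inhibition and lower numbers for stronger inhibition.
Compound 2 `CCCC/N=C/c1cc2cc(C)ccc2[nH]c1=O` gives 43300 nM in this assay.
Compound 3 `N/N=C/c1cc2ccccc2[nH]c1=O` gives 20600 nM in this assay.

Among these three, compound 3 holds the lowest number in this assay; the value of compound 2 lies above it, and compound 1 lies far above both. For the measured compounds named here, the one step measured on the double-bonded nitrogen, a 59-fold lower number from compound 1 to compound 3 (1.77 log units; beyond the scatter), shows how much the group on that nitrogen can move the number.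

Compound 4 `CCCC/N=C/c1cc2ccccc2[nH]c1=O` differs from compound 3 by butyl in place of amino on a double-bonded nitrogen. Going by the values given here, no measured step covers this exact exchange. The step from compound 1 to compound 3 went in the other direction, from a chain to amino, and lowered the number sharply. Compound 2 carries the same butyl on the same nitrogen and gives a higher number than compound 3, though it also bears a methyl on the core, so the two values are only a guide. Taken together, compound 4 is expected to move upward, by a 1.9-fold higher number from compound 3 to compound 4 (0.29 log units; within the scatter). The estimate for compound 4 in this assay is 40000 nM, within a range of 15000 nM to 120000 nM.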

Compound 4, half-maximal inhibitory concentration: 1810000 nM
For compound 4 the middle estimate is 45-fold (1.66 log units) below the measured one; measured number outside the range, above it.
By their numbers in this assay, from the lowest: compound 3; then compound 2; then compounds 1 and 4 (each within the scatter of the next).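

In this assay, the butyl chain on the double-bonded nitrogen gives no advantage over the chain of compound 1, as a 1.5-fold higher number from compound 1 to compound 4 (0.17 log units; within the scatter) lies within the scatter, while an 88-fold higher number from compound 3 to compound 4 (1.94 log units; beyond the scatter) sets amino clearly apart from butyl at this position. The methyl on the aromatic carbon also proves decisive with butyl in place, as a 42-fold higher number from compound 2 to compound 4 (1.62 log units; beyond the scatter) shows that compound 2 owes its much lower number to that methyl and that its value was no guide to the unmethylated pair. Nothing available explains either step.

The compounds shown leave open whether a methylamino or hydroxy group on this nitrogen would keep the low number seen with amino. They also leave open whether a methyl on the same aromatic carbon would lower the number with amino on the nitrogen, as it does with butyl.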